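The source may hold more compounds than are shown below. What is called first, only, known or untested is meant among the compounds shown, and "the series" means these compounds.

Working notes on the series.

Three compounds have numbers in a functional assay on PC-3 cells (Homo sapiens) for cytotoxicity, read by MTT assay, with a stated time of 48 h; on this read-out higher numbers stand for weaker inhibition and lower numbers for stronger inhibition. Compound 1 `CCN(CC)CC(=O)N1N=C(C)CC1c1ccccc1O` gives 25900 nM and compound 2 `CC(=O)Oc1ccccc1C1CC(C)=NN1C(=O)CN1CCC(O)CC1` gives 25600 nM; the two stand within the scatter of each other. Compound 3 `O=C(c1ccccc1Cl)N1N=C(c2cc3ccccc3oc2=O)CC1c1ccccc1` gives 6370 nM, the lowest of the three numbers, with its gap to compound 2 and to compound 1 each beyond the scatter. Going by the values given here, no pair of measured compounds differs in a single place, so no step is computed among them.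

Among the compounds with values here, compound 4 `O=C(CN1CCCC1)N1N=C(c2cc3ccccc3oc2=O)CC1c1ccccc1` is the one compound awaiting measurement in this assay. It differs from compound 3 in one place: (pyrrolidin-1-yl)methyl in place of 2-chlorophenyl on a carbonyl carbon. Compounds 1 and 2, which also carry an aminomethyl group on a carbonyl carbon, sit higher than compound 3 in this assay, but they differ from compound 4 in more than one place and their values are noted only for what they show.

The expected step of a 2.4-fold higher number from compound 3 to compound 4 (0.37 log units; beyond the scatter) is a moderate move towards a higher number, with a wide range allowed. Compound 4 is estimated at 15000 nM in this assay, between 5000 nM and 45000 nM.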

Compound 4, half-maximal inhibitory concentration: 50200 nM
Estimate against measurement, compound 4: 3.3-fold (0.52 log units) below; measured number above the stated range.
By their numbers in this assay, from the lowest: compound 3; then compounds 2, 1 and 4 (each within the scatter of the next).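

In this assay, going by these compounds alone, the single change at this position, (pyrrolidin-1-yl)methyl in place of 2-chlorophenyl on a carbonyl carbon, gives a 7.9-fold higher number from compound 3 to compound 4 (0.90 log units; beyond the scatter) and shows that the number responds to what this position carries. Within the data shown here, the earlier compounds offered no single-place comparison, making this the first reading of the position with the rest of the structure held fixed, and of this pair the 2-chlorophenyl compound has the lower number. Nothing on hand accounts for the size or direction of the step.

This one pair cannot separate the departure of 2-chlorophenyl from the arrival of (pyrrolidin-1-yl)methyl. It also leaves open how an unsubstituted phenyl, a morpholine in place of the pyrrolidine ring, or a longer chain between the carbonyl and the amine would read at this position.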